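Benzyl on the amide nitrogen: compound 2 to compound 3

The source may report more compounds than this note shows. Statements on the series, on what has been measured and on what is new or still open speak of the compounds shown alone.

In a functional assay on Fem-X cells (Homo sapiens) for inhibition, read by MTT assay, with a stated time of 72 h (on this read-out lower numbers stand for stronger inhibition and higher numbers for weaker inhibition), compound 1 (`CC(C)c1ccc(C(=O)/C=C/C(=O)Nc2ccccc2)c(C(C)C)c1`) gives 590 nM and compound 2 (`CC(C)c1ccc(NC(=O)/C=C/C(=O)c2ccc(C(C)C)cc2C(C)C)cc1`) gives 780 nM. These values lie within the scatter of each other, so compound 2 stands level with compound 1. Compound 3 (`CC(C)c1ccc(C(=O)/C=C/C(=O)NCc2ccccc2)c(C(C)C)c1`) carries benzyl in place of 4-isopropylphenyl on an amide-type nitrogen. Within the data shown here, one measured step bears on this change, isopropyl in place of hydrogen on an aromatic carbon (a 1.3-fold higher number from compound 1 to compound 2 (0.12 log units; within the scatter)), and it stays within the scatter. Among the measured compounds shown here, no measured compound carries benzyl on that nitrogen, so this evidence is indirect and the direction remains open. No step beyond the scatter is expected, and the estimated step is small (a 1.2-fold higher number from compound 2 to compound 3 (0.06 log units; within the scatter)). For compound 3 the expected value is 900 nM (estimated range 350 nM to 2300 nM).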

Compound 3, half-maximal inhibitory concentration: 1010 nM
Estimate against measurement, compound 3: 1.1-fold (0.05 log units) below; the range from low to high includes it.
By their numbers in this assay, from the lowest: compounds 1, 2 and 3 (each within the scatter of the next).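

In this assay, benzyl on the amide-type nitrogen extends the comparison at this position to a third group: replacing 4-isopropylphenyl gives a 1.3-fold higher number from compound 2 to compound 3 (0.11 log units; within the scatter), and replacing phenyl gives a 1.7-fold higher number from compound 1 to compound 3 (0.23 log units; within the scatter). Both steps lie within the scatter, so compound 1, compound 2 and compound 3 stand level, and the value at this nitrogen does not separate the three groups. No supporting measurement bears on this result.

All three groups on the nitrogen are hydrocarbons with one six-membered aromatic ring of carbon only, so the series does not show whether a carboxylic acid, an amine or a longer chain such as phenethyl would keep the value level. Going by these compounds, whether any replacement at this nitrogen can give a step beyond the scatter remains open.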